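From a Free Hydroxy to a Second Ethoxy

The compounds below may be only part of what the source reports. "The series", "measured", "known", "first", "only" and "open" are said of these compounds alone.

Three related compounds have been measured in a functional assay, read by spectrophotometry, with a stated time of 5 min; on this read-out higher numbers stand for weaker inhibition and lower numbers for stronger inhibition. Compound 1 (`COc1cc(/C=C/C(=O)C(=Cc2ccc(O)c(O)c2)C(=O)/C=C/c2ccc(O)c(OC)c2)ccc1O`) gives 2200 nM, compound 2 (`COc1cc(/C=C/C(=O)C(=Cc2ccccc2)C(=O)/C=C/c2ccc(O)c(OC)c2)ccc1O`) gives 8580 nM, and compound 3 (`CCOc1cc(C=C(C(=O)/C=C/c2ccc(O)c(OCC)c2)C(=O)/C=C/c2ccc(O)c(OCC)c2)ccc1O`) gives 5140 nM. The numbers for compound 3 and compound 2 lie within the usual scatter of each other, so they cannot be told apart. The number for compound 3 is higher than that for compound 1, and that gap lies beyond the scatter.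

Compound 4 (`CCOc1cc(/C=C/C(=O)C(=Cc2ccc(OCC)c(OCC)c2)C(=O)/C=C/c2ccc(O)c(OCC)c2)ccc1O`) changes compound 3 in one place, with ethyl in place of hydrogen on an oxygen on an aromatic ring. This turns 3-ethoxy-4-hydroxyphenyl into 3,4-diethoxyphenyl.

Within the data shown here, no measured step shows this exact change. The nearest guide is a 3.9-fold higher number from compound 1 to compound 2 (0.59 log units; beyond the scatter), a modest step beyond the scatter, in which phenyl replaced 3,4-dihydroxyphenyl. That step also removes hydroxy, but it leaves no ether behind, so it is only a loose guide. A rise in the same direction but of smaller size seems likely, and it may not clear the scatter.

The expected step is a 1.6-fold higher number from compound 3 to compound 4 (0.19 log units; within the scatter). For compound 4, the estimated value is 8000 nM, with an expected range of 3500 nM to 18000 nM.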

Compound 4, half-maximal inhibitory concentration: 20200 nM
Compound 4: the middle estimate sits 2.5-fold (0.40 log units) below what was measured; measured number above the stated range.
By their numbers in this assay, from the lowest: compound 1; then compounds 3 and 2 (each within the scatter of the next); then compound 4.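

In this assay putting ethyl on the free hydroxy of the 3-ethoxy-4-hydroxyphenyl group gives a 3.9-fold higher number from compound 3 to compound 4 (0.59 log units; beyond the scatter) and so carries the number clearly past the scatter, which shows that this single change on an oxygen on an aromatic ring is enough to weaken inhibition. Among these compounds, the only earlier step at this group (a 3.9-fold higher number from compound 1 to compound 2 (0.59 log units; beyond the scatter)) took away both of its hydroxy groups and left no oxygen there at all, whereas here the oxygen stays and only its hydrogen is replaced, and inhibition still weakens. Among the compounds shown here, nothing measured so far speaks to the reason for this loss.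

The compounds shown leave open whether the rise belongs to ethyl in particular or to any group on this oxygen, a question that a methoxy, a longer chain such as propoxy, or an amine in place of the hydroxy would help to settle. They also leave open whether ethyl on the free hydroxy groups that compound 4 still carries elsewhere would weaken inhibition in the same way.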